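Trimethoxyphenyl chalcone analogues on UO-31 cells

A few compounds are considered here, and "the series" means these few. Any claim that something is new, unique, unknown or untested is made for them only; others in the source may bear on it.

Of the compounds shown here, three of a shared chalcone-pyrazole core have been measured. In a functional assay on UO-31 cells (Homo sapiens) for inhibition, read by sulforhodamine B assay, with a stated time of 48 h (a higher number here means a weaker inhibitor of growth, a lower number a stronger inhibitor of growth), compound 1 `COc1ccc(-c2cc(/C=C/C(=O)c3ccc(N)cc3)[nH]n2)cc1` gives 1180 nM, while compound 2 `COc1ccc(-c2cc(/C=C/C(=O)c3ccc(N)cc3)[nH]n2)cc1OC` gives 3030 nM. Compound 1 differs from compound 2 by hydrogen in place of methoxy on an aromatic carbon, and that change made a 2.6-fold lower number from compound 2 to compound 1 (0.41 log units; beyond the scatter). Compound 3 `COc1cc(C(=O)/C=C/c2cc(-c3cc(OC)c(OC)c(OC)c3)n[nH]2)cc(OC)c1OC` gives 1190 nM in this assay; its value and that of compound 1 lie within the scatter of each other, and the difference between the cores of compound 2 and compound 3 is not broken down here.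

Compound 4 `COc1ccc(-c2cc(/C=C/C(=O)c3cc(OC)c(OC)c(OC)c3)[nH]n2)cc1OC` has not yet been measured. It differs from compound 3 by hydrogen in place of methoxy on an aromatic carbon. This is the same kind of change as that from compound 2 to compound 1, though the place in compound 3 is also meta to a methoxy group, which the place in compound 2 is not. Within the data shown here, because compound 3 gives 1190 nM and the earlier step was a 2.6-fold lower number from compound 2 to compound 1 (0.41 log units; beyond the scatter), a step of a 2.0-fold lower number from compound 3 to compound 4 (0.30 log units; within the scatter) is expected, somewhat smaller than the precedent given that only one such step is known. Compound 4 is therefore estimated at 600 nM, with a likely range from 250 nM to 1500 nM in this assay.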

Compound 4, concentration for 50% growth inhibition: 1270 nM
Compound 4: middle estimate off by 2.1-fold (0.33 log units), on the low side, within the range that was stated.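

In this assay, putting hydrogen in place of methoxy on an aromatic carbon gave a 1.1-fold higher number from compound 3 to compound 4 (0.03 log units; within the scatter), so on this core the two values lie within the scatter of each other. The step seen on the first core therefore did not carry over to the second: the same change on two cores in this assay, a 2.6-fold lower number (0.41 log units; beyond the scatter) from compound 2 to compound 1 and a 1.1-fold higher number (0.03 log units; within the scatter) from compound 3 to compound 4, 2.7-fold (0.44 log units) apart, beyond the scatter of two such steps. Among these compounds, this shows that the same change need not give the same result on these two cores, but with only two pairs it does not show which difference between the cores matters, or how the change would behave on a further core.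

The compounds shown leave open what other groups would do in this place, for example a hydroxyl group or a fluorine atom in place of the methoxy group. Also open, on these data alone, is whether the gap between the two steps would hold in other cell lines, as these steps come from a single cell line and a single read-out.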